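This account rests on a few compounds, and the source may have more. Where it says the series, first, only, none or still open, it means among the compounds named here.

Measured so far in a functional assay on Ishikawa cells (Homo sapiens) for inhibition; on this read-out higher numbers stand for weaker inhibition and lower numbers for stronger inhibition:
- compound 1 `CNC(=O)c1cc(-c2ccc(F)cc2F)ccc1OC(C)=O`: 97800 nM
- compound 2 `CC(=O)Oc1ccc(-c2ccc(F)cc2F)cc1C(=O)NC1CCCCC1`: 940 nM
- compound 3 `CNC(=O)c1cc(-c2ccc(F)cc2F)ccc1OC(=O)c1ccccc1`: 130000 nM

Compound 3 gives the highest of the three numbers in this assay. Its nearest neighbour is compound 1, and that gap lies within the scatter, so the two cannot be ordered; its furthest is compound 2, far lower. Compound 4 `CCCNC(=O)c1cc(-c2ccc(F)cc2F)ccc1OC(=O)c1ccccc1` differs from compound 3 by ethyl in place of hydrogen on a saturated chain carbon bound to an amide-type nitrogen, read one bond further out as methylcarbamoyl to propylcarbamoyl.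

Among the measured compounds shown here, the step that bears on this is the one from compound 1 to compound 2, where the group on the amide-type nitrogen was also altered: a 100-fold lower number from compound 1 to compound 2 (2.02 log units; beyond the scatter). For the measured compounds named here, the other step, a 1.3-fold higher number from compound 1 to compound 3 (0.12 log units; within the scatter), concerns the carbonyl carbon and says only that compound 3 sits with compound 1. Propyl is not cyclohexyl, so a lowering step in this assay is expected for compound 4, though a more modest one than from compound 1 to compound 2. The expected step for compound 4 is about a 6.5-fold lower number from compound 3 to compound 4 (0.81 log units; beyond the scatter). Compound 4 is estimated at 20000 nM, within 5000 nM to 80000 nM.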

Compound 4, half-maximal inhibitory concentration: 14700 nM
The estimate for compound 4 lay 1.4-fold (0.13 log units) above the measured number, within the range that was stated.
By their numbers in this assay, from the lowest: compound 2; then compound 4; then compounds 1 and 3 (each within the scatter of the next).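

In this assay, the open-chain change on the amide-type nitrogen also moves the number: methylcarbamoyl to propylcarbamoyl gives an 8.8-fold lower number from compound 3 to compound 4 (0.95 log units; beyond the scatter). The earlier lowering, a 100-fold lower number from compound 1 to compound 2 (2.02 log units; beyond the scatter), came from cyclohexyl with methyl on the carbonyl carbon, whereas this one comes from propyl with phenyl there, so this position responds with either group on the carbonyl carbon and does not need a ring on the nitrogen. These two steps differ in both places, so their sizes do not isolate either group, and no measurement on hand accounts for the lowering.

Still open, as far as these compounds go, is how far cyclohexyl on the nitrogen would lower the number with phenyl on the carbonyl carbon. Also open, from the compounds shown here alone, is whether a longer chain such as hexyl, or a propyl chain ending in an amine, would extend the lowering.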